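The compounds below may be only part of what the source reports. "The series", "measured", "known", "first", "only" and "open" are said of these compounds alone.

Compound 1 `COC(=O)c1ccsc1NC(=O)[C@@H]1CCCN1`: > 250 ug/mL
Compound 2 `O=C(Oc1ccccc1)c1ccsc1NC(=O)[C@@H]1CCCN1`: > 250 ug/mL

In a functional assay on HeLa cells (Homo sapiens) for inhibition (a higher number here means a weaker inhibitor of growth, a lower number a stronger inhibitor of growth), compound 2 gives > 250 ug/mL, which is a limit of the assay and not a number. Compound 1 gives > 250 ug/mL, also a limit. Going by the values given here, the only measured change is therefore a step that the two limits leave unreadable from compound 1 to compound 2. Compound 3 `O=C1CC[C@@H](COC(=O)c2ccsc2NC(=O)[C@@H]2CCCN2)N1` carries (5-oxopyrrolidin-2-yl)methyl in place of phenyl on an oxygen next to a carbonyl group.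

Among the compounds with values here, the sole guide is the limit of > 250 ug/mL in this assay, at which 2 of the 2 values shown sit. Both esters measured so far sit there, so the data give no direction for this change. No step beyond the scatter is expected in this assay, and compound 3 will probably also be reported only as a limit. The expected change is a number no higher from compound 2 to compound 3 (the limit leaves the size open). The estimate for compound 3 is 250 ug/mL, with an expected range from 100 ug/mL to 500 ug/mL.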

Compound 3, concentration for 50% growth inhibition: 191 ug/mL
The estimate for compound 3 lay 1.3-fold (0.12 log units) above the measured number; measured number inside the range.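

In this assay, going by these compounds alone, compound 3 gives 191 ug/mL, the first actual number at this position on an oxygen next to a carbonyl group, so a change here can yield a measured number. Placing (5-oxopyrrolidin-2-yl)methyl in place of phenyl gives an at least 1.3-fold lower number from compound 2 to compound 3 (0.11 log units; that floor lies within the scatter), and placing 5-oxopyrrolidin-2-yl in place of hydrogen on the chain carbon gives an at least 1.3-fold lower number from compound 1 to compound 3 (0.11 log units; that floor lies within the scatter), so neither step is shown to exceed the usual scatter. The step between compound 1 and compound 2 cannot be read, as both sit at a limit of the assay and not a number: the limit of > 250 ug/mL in this assay, at which 2 of the 3 values shown sit.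

Still open, as far as these compounds go, is whether the true size of these steps goes beyond the scatter, and which part of the (5-oxopyrrolidin-2-yl)methyl group matters. A cyclopentylmethyl group, or a chain ending in an amine or a carboxylic acid, would help to separate these possibilities.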